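The source may hold more compounds than are shown below. What is called first, only, known or untested is meant among the compounds shown, and "the series" means these compounds.

Measured in a functional assay (blood) for inhibition, with Homo sapiens as the target; a lower number here means a stronger inhibitor, a higher number a weaker inhibitor:
Compound 1 `OC1(c2cccc(COc3ccc4c(-c5ccoc5)cc(C5=NCCO5)cc4c3)c2)CCOCC1`: 50 nM
Compound 2 `O=C(c1ccccc1)c1cc(-c2ccoc2)c2ccc(OCc3cccc(C4(O)CCOCC4)c3)cc2c1`: 200 nM

Compound 2 holds the higher of the two numbers and is the weaker inhibitor of the pair. Among the measured compounds shown here, the only measured step, a 4.0-fold higher number from compound 1 to compound 2 (0.60 log units; beyond the scatter), lies beyond the scatter and is modest. It came with benzoyl entering on an aromatic carbon.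

Compound 3 `OC1(c2cccc(COc3ccc4c(-c5ccoc5)cc(Cc5nccs5)cc4c3)c2)CCOCC1` changes that same place: (1,3-thiazol-2-yl)methyl in place of benzoyl on an aromatic carbon. In words, (1,3-thiazol-2-yl)methyl stands in place of benzoyl on an aromatic carbon, meta to a furan-3-yl group.

That single step bears directly on the change, since it shows that this assay responds to the group at this place, and benzoyl is the group that gave the higher number. The (1,3-thiazol-2-yl)methyl group itself has not been measured on this core, so the direction is only tentatively expected, and the size should not exceed that of the measured step. The estimated step is a 2.0-fold lower number from compound 2 to compound 3 (0.30 log units; within the scatter), toward a lower number. For compound 3 the estimated value is 100 nM, with an expected range from 35 nM to 300 nM.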

Compound 3, half-maximal inhibitory concentration: 660 nM
Compound 3: middle estimate off by 6.6-fold (0.82 log units), on the low side; the whole stated range lies below it.
By their numbers in this assay, from the lowest: compound 1; then compound 2; then compound 3.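

The position proves more sensitive than the first pair could show: in this assay, exchanging benzoyl for (1,3-thiazol-2-yl)methyl gives a 3.3-fold higher number from compound 2 to compound 3 (0.52 log units; beyond the scatter), so benzoyl no longer marks the weak end of the series and a smaller group with one more hydrogen-bond acceptor does not restore the lower number. Against the five-membered non-aromatic ring of compound 1, the same place now spans a 13-fold higher number from compound 1 to compound 3 (1.12 log units; beyond the scatter), and in these three compounds both groups carrying an aromatic ring stand on the weaker side of that ring, with no compound shown going against this. No measured property of these compounds bears on this order, so the result stands here as an observation without an explanation.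

Benzoyl and (1,3-thiazol-2-yl)methyl differ in both the ring and the link that joins it to the core, so the compounds shown cannot separate the contribution of the ring from that of the link. As far as these compounds go, it also remains open how this assay would respond at the same place to a primary amide, a carboxylic acid or an amine, or to the 1,3-thiazol-2-yl ring joined directly to the core.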